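The source may hold more compounds than are shown below. What is called first, only, known or untested is meant among the compounds shown, and "the series" means these compounds.

Measured so far in a functional assay on CCRF-CEM cells (Homo sapiens) for inhibition, read by sulforhodamine B assay, with a stated time of 48 h; a lower number here means a stronger inhibitor of growth, a higher number a weaker inhibitor of growth:
- compound 1 `COc1cc(-c2cc(/C=C/C(=O)c3ccc(N)cc3)[nH]n2)cc(OC)c1OC` gives 4170 nM
- compound 2 `COc1ccc(C(=O)/C=C/c2cc(-c3cc(OC)c(OC)c(OC)c3)n[nH]2)cc1OC` gives 3930 nM

Within the data shown here, compound 2 stands lowest of the two numbers in this assay, but its nearest neighbour is compound 1, and the only step recorded, a 1.1-fold lower number from compound 1 to compound 2 (0.03 log units; within the scatter), is within the scatter; so the two compounds are not separated by the data.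

The next member is compound 3 `COc1ccc(C(=O)/C=C/c2cc(-c3cc(OC)c(OC)c(OC)c3)n[nH]2)cc1`. The change from compound 2 is hydrogen in place of methoxy on an aromatic carbon; cut one bond further out, it reads 3,4-dimethoxyphenyl to 4-methoxyphenyl, on the aryl that sits on the carbonyl carbon.

Among the measured compounds shown here, no measured step covers the loss of this methoxy. For the measured compounds named here, the one step that touches the same aryl, a 1.1-fold lower number from compound 1 to compound 2 (0.03 log units; within the scatter), exchanged the whole group for another and moved the number by less than the scatter. On that basis the aryl on the carbonyl appears tolerant of change, and the expected step of a 1.0-fold higher number from compound 2 to compound 3 (0.01 log units; within the scatter) is none beyond the scatter. Compound 3 is therefore estimated at 4000 nM, with a range of 1500 nM to 10000 nM in this assay.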

Compound 3, concentration for total growth inhibition: 5850 nM
Compound 3: the middle estimate sits 1.5-fold (0.17 log units) below what was measured; measured number inside the range.
By their numbers in this assay, from the lowest: compounds 2, 1 and 3 (each within the scatter of the next).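

Notes on the aryl on the carbonyl carbon: in this assay the 3,4-dimethoxyphenyl to 4-methoxyphenyl change gives the first direct reading of this single methoxy, and the step (a 1.5-fold higher number from compound 2 to compound 3 (0.17 log units; within the scatter)) leaves compound 3 unseparated from compound 2. The exchange of amino for methoxy on the same aryl (a 1.4-fold higher number from compound 1 to compound 3 (0.15 log units; within the scatter)) is also within the scatter, so amino, methoxy and the pair of methoxy groups on this aryl cannot be told apart in this assay, for these three compounds only. No measured evidence bears on why these three compounds read alike.

Every aryl on the carbonyl shown so far carries amino or methoxy, so it remains open whether an unsubstituted phenyl, a chloro or trifluoromethyl substituent, or a carboxylic acid on this ring would also stay within the scatter. The other aryl group, with its three methoxy groups, is the same throughout, so nothing here tells how the series responds to a change there, for example to a single methoxy or to an amine.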